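Amide to urea on a shared sulfonate core

The source may report more compounds than this note shows. Statements on the series, on what has been measured and on what is new or still open speak of the compounds shown alone.

Compound 2 `O=C(CCCl)Nc1ccc(S(=O)(=O)Oc2ccccc2I)cc1` gives 4200 nM in a functional assay on HT-1080 cells (Homo sapiens) for antiproliferative activity, read by sulforhodamine B assay, with a stated time of 48 h (on this read-out lower numbers stand for stronger inhibition and higher numbers for weaker inhibition), the lowest of the two numbers measured; compound 1 `CCCCCC(=O)Nc1ccc(S(=O)(=O)Oc2ccccc2I)cc1` gives 9600 nM. Among the compounds with values here, the only step seen, a 2.3-fold lower number from compound 1 to compound 2 (0.36 log units; beyond the scatter), is modest. Compound 3 `CCNC(=O)Nc1ccc(S(=O)(=O)Oc2ccccc2I)cc1` differs from compound 2 by ethylamino in place of 2-chloroethyl on a carbonyl carbon, turning the amide into a urea. Within the data shown here, no measured step touches this change, so the expected size is taken from the single modest step seen, with no direction favoured. Compound 3 is estimated at 6000 nM, with a range of 1500 nM to 20000 nM, which means an expected step of a 1.4-fold higher number from compound 2 to compound 3 (0.15 log units; within the scatter).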

Compound 3, half-maximal inhibitory concentration: 140 nM
The estimate for compound 3 lay 43-fold (1.63 log units) above the measured number; the measured number lies below the stated range.
By their numbers in this assay, from the lowest: compound 3; then compound 2; then compound 1.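

With ethylamino on the carbonyl carbon, the amide becomes a urea, and this assay shows a 30-fold lower number from compound 2 to compound 3 (1.48 log units; beyond the scatter) as well as a 69-fold lower number from compound 1 to compound 3 (1.84 log units; beyond the scatter) in the comparison with the pentyl amide. This position can therefore shift the number far more than the change in the amide chain alone had shown, and the urea brings one more hydrogen-bond donor. Nothing available explains the gain.

On these data alone, whether the urea hydrogen matters or the ethyl group also contributes stays open. A dimethylamino group, a longer chain such as butylamino, or a cyclohexylamino group on the same carbonyl carbon would begin to separate these.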